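Cyano sugar nucleosides: base hydroxy to amino step

The source may report more compounds than this note shows. Statements on the series, on what has been measured and on what is new or still open speak of the compounds shown alone.

Measured so far:
compound 1, `N#C[C@H]1[C@@H](O)[C@H](n2cc(F)c(O)nc2=O)O[C@H](CO)[C@H]1O`: 819000 nM
compound 2, `N#C[C@H]1[C@@H](O)[C@H](n2ccc(O)nc2=O)O[C@H](CO)[C@H]1O`: 811000 nM

Both numbers come from a functional assay on HeLa cells (Homo sapiens); a higher number here means a weaker inhibitor, a lower number a stronger inhibitor. The values of compound 1 and compound 2 sit within the scatter of each other, so the pair a 1.0-fold lower number from compound 1 to compound 2 (0.00 log units; within the scatter) is read as no change; compound 2 is therefore not distinguishable from compound 1 on this assay.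

The next compound, compound 3, `N#C[C@H]1[C@@H](O)[C@H](n2ccc(N)nc2=O)O[C@H](CO)[C@H]1O`, differs from compound 2 in a single place: amino in place of hydroxy on an aromatic carbon. The change sits on an aromatic carbon of a six-membered aromatic ring with 2 nitrogen, next to the ring nitrogen and para to a large group, the shared core and the sugar being untouched.

Going by the values given here, only one measured step exists, and it exchanges fluoro for hydrogen at a different carbon; it does not bear on a hydroxy-to-amino swap. Among the compounds with values here, with no relevant precedent, the working expectation is a step within the scatter, wide in both directions. Compound 3 is expected to give an estimate of 600000 nM, range 120000 nM to 1500000 nM, corresponding to an expected step of a 1.4-fold lower number from compound 2 to compound 3 (0.13 log units; within the scatter).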

Compound 3, half-maximal inhibitory concentration: > 750000 nM
Compound 3: only a limit was reported; the forecaster's own chance of this, stated with the estimate: 20%; middle value at least 1.2-fold (0.09 log units) from the limit.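

In this assay compound 3 gives > 750000 nM, which is a limit and not a number. The step from compound 2 to compound 3 cannot be read: the limit of > 750000 nM in this assay, at which 1 of the 3 values shown sits.

The compounds shown leave open whether amino in place of hydroxy on this aromatic carbon changes the number in this assay at all, and in which direction.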